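Adding ethoxy to compound 2: working notes

A few compounds are considered here, and "the series" means these few. Any claim that something is new, unique, unknown or untested is made for them only; others in the source may bear on it.

Of the compounds shown here, two on the shared core have been read so far. In a functional assay on K562 cells (Homo sapiens) for antiproliferative activity, read by MTT assay, with a stated time of 24 h (on this read-out lower numbers stand for stronger inhibition and higher numbers for weaker inhibition), compound 1 `COc1ccc(C(=O)/C=C/c2ccc([N+](=O)[O-])cc2)c2c1C=CC(C)(C)O2` gives 7770 nM. In this assay compound 2 `COc1ccc(C(=O)/C=C/c2ccc(O)cc2)c2c1C=CC(C)(C)O2` gives > 10000 nM, which is a limit of the assay and not a number. Compound 2 therefore has no measured standing of its own, only (the limit of > 10000 nM in this assay, at which 1 of the 2 values shown sits).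

The next compound, compound 3 `CCOc1cc(/C=C/C(=O)c2ccc(OC)c3c2OC(C)(C)C=C3)ccc1O`, keeps the hydroxy group of compound 2 and differs from it by ethoxy in place of hydrogen on an aromatic carbon, ortho to the hydroxy group. Going by the values given here, only one measured step is available, an at least 1.2-fold higher number from compound 1 to compound 2 (0.10 log units; that floor lies within the scatter). That step is hydroxy in place of nitro, so it bears on the new change only indirectly and gives no size for an added ethoxy. No step beyond the scatter is therefore expected in this assay, and another reading at the limit is the likelier outcome. The expected change is a step that the limit leaves unreadable from compound 2 to compound 3. For compound 3 the estimated value is 12000 nM, with an expected range of 5000 nM to 30000 nM.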

Compound 3, half-maximal inhibitory concentration: > 10000 nM
Compound 3 gave a limit, no number (the forecaster's own chance of this, stated with the estimate: 65%); the middle value is on the limit's open side.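

No step from compound 2 to compound 3 can be read in this assay, because both compounds give a limit of the assay and not a number: the limit of > 10000 nM in this assay, at which 2 of the 3 values shown sit.

The compounds shown leave open whether ethoxy in place of hydrogen on an aromatic carbon changes the read-out in this assay, and if so in which direction and by how much.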